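A few compounds are considered here, and "the series" means these few. Any claim that something is new, unique, unknown or untested is made for them only; others in the source may bear on it.

Compound 2 `Clc1ccc(/C=N/N(Cc2ccccc2)Cc2ccccc2)cc1` and compound 1 `COc1ccc(/C=N/N(Cc2ccccc2)Cc2ccccc2)cc1` share one core and differ only in one aromatic substituent. In an assay on liver (Sus scrofa) for inhibition of glucose-6-phosphatase catalytic subunit 1 (Homo sapiens), using microsomes (a lower number here means a stronger inhibitor, a higher number a weaker inhibitor), compound 1 gives 220 nM, and compound 2 gives 240 nM; the step of a 1.1-fold higher number from compound 1 to compound 2 (0.04 log units; within the scatter) leaves the two within the scatter of each other, so neither stands apart on the numbers shown. Compound 3 `Oc1ccc(/C=N/N(Cc2ccccc2)Cc2ccccc2)cc1` differs from compound 2 by hydroxy in place of chloro on an aromatic carbon. Among the measured compounds shown here, the only step measured so far, from compound 1 to compound 2, swapped one small group for another without moving the number, so for compound 3 the expectation is a step of a 1.3-fold higher number from compound 2 to compound 3 (0.10 log units; within the scatter) that stays close to the scatter, with an estimated value of 300 nM, ranging from 100 nM to 900 nM.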

Compound 3, half-maximal inhibitory concentration: 2400 nM
Estimate against measurement, compound 3: 8.0-fold (0.90 log units) below, outside the stated range (above it).
By their numbers in this assay, from the lowest: compounds 1 and 2 (each within the scatter of the next); then compound 3.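

At this position the choice of group does matter in this assay: chloro and methoxy could not be told apart, yet hydroxy gives a 10-fold higher number from compound 2 to compound 3 (1.00 log units; beyond the scatter) and likewise an 11-fold higher number from compound 1 to compound 3 (1.04 log units; beyond the scatter) in a step that only removes the methyl from the oxygen. So the earlier flat result does not extend to every small group, and hydroxy brings a hydrogen-bond donor that chloro lacks. Nothing available explains the loss. On these data alone, whether that donor is what counts remains open, and an amine at this position could help test it.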